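Cyano for chloro on the benzyl arm: cytotoxicity notes

The compounds below may be only part of what the source reports. "The series", "measured", "known", "first", "only" and "open" are said of these compounds alone.

Measured compounds:
compound 1, `O=C1N(Cc2cccc(Cl)c2)c2cccn2S(=O)(=O)N1Cc1ccccc1`: 196000 nM
compound 2, `O=C1N(Cc2cccc(Cl)c2)c2cccn2S(=O)(=O)N1Cc1cccc(F)c1`: 208000 nM
compound 3, `O=C1N(Cc2ccccc2Br)c2cccn2S(=O)(=O)N1Cc1cccc(F)c1`: > 269000 nM, a limit of the assay rather than a number

In an ADME assay on MT4 cells (Homo sapiens) for cytotoxicity, read by MTT assay, with a stated time of 5 days (a lower number here means that less compound is tolerated, a higher number that more compound is tolerated), compound 1 gives 196000 nM. Compound 2 gives 208000 nM, and the two sit together within the scatter, so neither can be set above the other. The value for compound 3 is a limit of the assay. For the measured compounds named here, of the three values shown, one sits at the limit of > 269000 nM in this assay, at which 1 of the 3 values shown sits, so only two numbers are available to place compound 1, and it sits with compound 2.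

Compound 4, `N#Cc1cccc(CN2C(=O)N(Cc3ccccc3)S(=O)(=O)n3cccc32)c1`, is still to be measured. It differs from compound 1 by cyano in place of chloro on an aromatic carbon.

Two measured steps are available, and neither is the same change. The step of a 1.1-fold higher number from compound 1 to compound 2 (0.03 log units; within the scatter) alters the other benzyl arm of the shared core. The step of an at least 1.2-fold higher number from compound 2 to compound 3 (0.11 log units; that floor lies within the scatter) alters the ring that carries the chloro in compound 1, but swaps the whole aryl group. Going by the values given here, both steps sit within the scatter, and no measured step exchanges chloro for cyano. The expectation for compound 4 is therefore a step of no size beyond the scatter, a 1.0-fold higher number from compound 1 to compound 4 (0.01 log units; within the scatter), in this assay. Compound 4 is expected to give 200000 nM, with a range from 100000 nM to 320000 nM. Since one value in this assay is a limit, a limit-only reading for compound 4 cannot be ruled out.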

Compound 4, half-maximal cytotoxic concentration: > 318000 nM
Compound 4 was reported as a limit (the forecaster's own chance of this, stated with the estimate: 25%); middle value at least 1.5-fold (0.20 log units) from the limit.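

In this assay, cyano in place of chloro on an aromatic carbon of the benzyl arm gives an at least 1.6-fold higher number from compound 1 to compound 4 (0.21 log units; that floor lies within the scatter). Compound 4 is reported as a limit of the assay, the second such reading among the compounds shown: the limit of > 318000 nM in this assay, at which 1 of the 4 values shown sits. Unlike the two earlier steps, this exchange alters only the group on the 3-chlorobenzyl arm, and 3-cyanobenzyl shows no sign of a lower number than 3-chlorobenzyl, although the floor of the step does not establish a real rise.

The compounds shown leave open where the actual value of compound 4 lies, and therefore whether the step from chloro to cyano truly exceeds the scatter or stays within it. They also leave open whether the same exchange behaves alike with the fluoro-bearing arm of compound 2 in place of the unsubstituted benzyl arm, and whether an amine or a carboxylic acid on that same aromatic carbon would keep the number this high in this assay.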